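From a benzyl amide to a dimethylphenyl amide

The compounds below may be only part of what the source reports. "The series", "measured", "known", "first", "only" and "open" are said of these compounds alone.

Going by the values given here, in a functional assay on A549 cells (Homo sapiens) for inhibition, read by MTT assay, with a stated time of 48 h (on this read-out higher numbers stand for weaker inhibition and lower numbers for stronger inhibition), compound 3 `COc1ccc2c(=O)c(/C=C/C(=O)NCc3ccccc3)coc2c1` gives 11800 nM, the only actual number among the three measured compounds. Compound 1 `COc1ccc(CNC(=O)/C=C/c2coc3cc(O)ccc3c2=O)cc1` reaches only the limit > 100000 nM. Compound 2 `O=C(/C=C/c1coc2cc(O)ccc2c1=O)NCc1ccccc1` likewise stops at the limit > 100000 nM. Because both sit at the limit of > 100000 nM in this assay, at which 2 of the 3 values shown sit, the step that the two limits leave unreadable from compound 1 to compound 2 cannot be sized, whereas an at least 8.4-fold lower number from compound 2 to compound 3 (0.92 log units; beyond the scatter) is clear. Compound 4 `COc1ccc2c(=O)c(/C=C/C(=O)Nc3cc(C)ccc3C)coc2c1` differs from compound 3 in that (2,5-dimethylphenyl in place of benzyl on an amide-type nitrogen). Neither measured step touches the amide nitrogen, so no measured change bears on this one; the step from compound 3 to compound 4 in this assay is therefore expected to be a 1.2-fold lower number from compound 3 to compound 4 (0.07 log units; within the scatter), not beyond the scatter. Compound 4 is estimated at 10000 nM, with a likely range from 3000 nM to 40000 nM.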

Compound 4, half-maximal inhibitory concentration: 15500 nM
For compound 4 the middle estimate is 1.6-fold (0.19 log units) below the measured one; measured number inside the range.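

Going by these compounds alone, the first change at the amide-type nitrogen, 2,5-dimethylphenyl in place of benzyl, gives a 1.3-fold higher number from compound 3 to compound 4 (0.12 log units; within the scatter), so in this assay the two compounds cannot be told apart. With the shared core carrying its methoxy group, this nitrogen therefore accepts either group without a measurable difference in this read-out. Nothing available here explains why the two groups read alike.

Going by these compounds, whether plain phenyl would read the same on this nitrogen remains open. So does the effect of a longer chain, an amine or a carboxylic acid there.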